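The source may hold more compounds than are shown below. What is called first, only, known or untested is meant among the compounds shown, and "the series" means these compounds.

Measured in an ADME assay on MDCK cells (Canis lupus familiaris) for permeability, in the apical to basolateral direction, with a stated time of 60 min, tested at 10 uM; on this read-out lower numbers stand for lower permeability and higher numbers for higher permeability:
- compound 1 `CCNc1ncc2cc(-c3ccc(-c4cncc(C)n4)cc3Cl)c(=O)n(CCCCN)c2n1`: 1.1 10^-6 cm/s
- compound 2 `CNc1ncc2cc(-c3ccc(-c4cncc(C)n4)cc3Cl)c(=O)n(C[C@H]3CC[C@H](N)CC3)c2n1`: 0.4 10^-6 cm/s
- compound 3 `CCNc1ncc2cc(-c3ccc(-c4cncc(C)n4)cc3Cl)c(=O)n(CCCO)c2n1`: 21 10^-6 cm/s

Compound 3 stands highest of the three, beyond the scatter from both others. Compound 4 `CCNc1ncc2cc(-c3ccc(-c4cncc(C)n4)cc3Cl)c(=O)n(CC3CCNC(=O)C3)c2n1` differs from it as follows: 2-oxopiperidin-4-yl in place of 2-hydroxyethyl on a saturated chain carbon bound to an aromatic nitrogen. In words, this is 2-oxopiperidin-4-yl in place of 2-hydroxyethyl on a saturated chain carbon bound to an aromatic nitrogen.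

Among the measured compounds shown here, the only measured step is large: a 19-fold higher number from compound 1 to compound 3 (1.28 log units; beyond the scatter). For the measured compounds named here, it is a different exchange, hydroxy in place of aminomethyl, so it shows only that one change on this chain can move the number far. Going by the values given here, no measured compound carries the entering ring, which leaves the expectation loose. A moderate drop in this assay is expected, starting from compound 3 at 21 10^-6 cm/s. The expected step is a 2.6-fold lower number from compound 3 to compound 4 (0.42 log units; beyond the scatter). The estimate for compound 4 is 8 10^-6 cm/s, with an expected range of 3 10^-6 cm/s to 20 10^-6 cm/s.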

Compound 4, apparent permeability: 10.6 10^-6 cm/s
Compound 4: the middle estimate sits 1.3-fold (0.12 log units) below what was measured, and the stated range covers the measured number.
By their numbers in this assay, from the lowest: compound 2; then compound 1; then compounds 4 and 3 (each within the scatter of the next).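

In this assay, 2-oxopiperidin-4-yl in place of 2-hydroxyethyl on this saturated chain carbon gives a 2.0-fold lower number from compound 3 to compound 4 (0.30 log units; within the scatter) and so stays within the scatter, which shows that a six-membered non-aromatic ring can stand here without a measurable change. Against 3-aminopropyl the same ring gives a 9.6-fold higher number from compound 1 to compound 4 (0.98 log units; beyond the scatter) as a step beyond the scatter, so high numbers at this place are not confined to the open hydroxy chain. No evidence bearing on the reason for either step is available.

Going by these compounds, whether a carboxylic acid or a longer hydroxy chain on this carbon would keep the number stays open.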